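Adding propyl to compound 3: working notes

This account rests on a few compounds, and the source may have more. Where it says the series, first, only, none or still open, it means among the compounds named here.

Measured so far in a physicochemical assay for lipophilicity, using the shake flask method, in phosphate buffer, measured as octanol-water partition, at pH 7.4 (a higher number here means a more lipophilic compound, a lower number a more polar compound), for the series:

- compound 1 `Cc1cn([C@H]2CCCN([C@H](CC(C)C)c3ccc(C(=O)O)c(Oc4cccc(Cl)c4)c3F)C2)c(=O)[nH]c1=O` at 0.92
- compound 2 `CCC[C@H](c1ccc(C(=O)O)c(Oc2cccc(Cl)c2)c1OC)N1CCC[C@H](n2cc(C)c(=O)[nH]c2=O)C1` at 0.08
- compound 3 `Cc1cn([C@H]2CCCN(Cc3ccc(C(=O)O)c(Oc4cccc(Cl)c4)c3F)C2)c(=O)[nH]c1=O` at -0.59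

Compound 3 stands lowest of the three at -0.59 in this set, with compound 2 nearest and compound 1 furthest. Compound 4 `CCC[C@H](c1ccc(C(=O)O)c(Oc2cccc(Cl)c2)c1F)N1CCC[C@H](n2cc(C)c(=O)[nH]c2=O)C1` differs from compound 3 by propyl in place of hydrogen on a saturated chain carbon bound to an amine nitrogen in a ring and an aromatic carbon in the form of propyl in place of hydrogen on a saturated chain carbon bound to an amine nitrogen in a ring and an aromatic carbon. Among the measured compounds shown here, the only measured step at this place is a number 1.51 log units lower from compound 1 to compound 3 (beyond the scatter) for hydrogen in place of isobutyl, and it runs the opposite way. Compound 4 differs elsewhere in the core from compound 2, which also carries propyl on that carbon and gives 0.08 as a looser guide. In this assay a higher number is therefore expected, with a step somewhat smaller than the measured one. The expected step is a number 1.14 log units higher from compound 3 to compound 4 (beyond the scatter) in size and direction. Compound 4 is estimated at 0.55 with an expected range from 0.15 to 0.95 in this measurement.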

Compound 4, distribution coefficient: 0.53
The estimate for compound 4 lay 0.02 log units above the measured number; the range from low to high includes it.
By their numbers in this assay, from the lowest: compound 3; then compound 2; then compound 4; then compound 1.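

In this assay, propyl in place of hydrogen on a saturated chain carbon bound to an amine nitrogen in a ring and an aromatic carbon gives a number 1.12 log units higher from compound 3 to compound 4 (beyond the scatter) and this confirms that the rise at this position is not specific to isobutyl. The chain shape still registers, with a number 0.39 log units lower from compound 1 to compound 4 (beyond the scatter) for hydrogen in place of methyl on a saturated chain carbon bound to two saturated chain carbons. Among the compounds shown here, the core also contributes with propyl held constant, since fluoro in place of methoxy on an aromatic carbon gives a number 0.45 log units higher from compound 2 to compound 4 (beyond the scatter) as the first measured step at that place.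

Still open, as far as these compounds go, is whether a longer chain or a cyclopropyl group on the same carbon would continue this trend. An amine or hydroxyl group carried on that chain also remains unplaced in this series. No measured evidence bears on what sets the size of these steps.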